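Compound 3 to compound 4: a thiophen-2-yl exchange

The compounds below may be only part of what the source reports. "The series", "measured", "known", "first", "only" and "open" are said of these compounds alone.

In a functional assay on SW 1116 cells (Homo sapiens) for cytotoxicity, read by MTT assay, with a stated time of 48 h (on this read-out lower numbers stand for stronger inhibition and higher numbers for weaker inhibition), compound 1 (`NNC(=O)CSc1nnc(-c2ccncc2)o1`) gives 3260 nM. Compound 2 (`O=C(CSc1nnc(-c2ccncc2)o1)N/N=C/c1ccc(F)cc1`) gives 15700 nM, and compound 3 (`O=C(CSc1nnc(-c2ccncc2)o1)N/N=C/c1cc(Br)ccc1O`) gives 8150 nM. Compound 3 therefore lies within the scatter of compound 2, while the number for compound 1 is lower than that of compound 3 by more than the scatter.

Compound 4 (`O=C(CSc1nnc(-c2ccncc2)o1)N/N=C/c1cccs1`) carries thiophen-2-yl in place of 5-bromo-2-hydroxyphenyl on a carbon with a double bond to nitrogen.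

For the measured compounds named here, only one measured step bears on this place: a 1.9-fold lower number from compound 2 to compound 3 (0.28 log units; within the scatter). That exchange of one ring substituent set for another stayed within the scatter, so no step beyond the scatter is expected here, although a single step is thin evidence. The expected step is a 1.2-fold higher number from compound 3 to compound 4 (0.09 log units; within the scatter), a small move towards a higher number that remains within the scatter. For compound 4 the estimated value is 10000 nM, with an expected range of 4000 nM to 25000 nM.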

Compound 4, half-maximal inhibitory concentration: 24900 nM
For compound 4 the middle estimate is 2.5-fold (0.40 log units) below the measured one; the measured number falls inside the stated range.
By their numbers in this assay, from the lowest: compound 1; then compounds 3, 2 and 4 (each within the scatter of the next, the first and the last beyond it).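

In this assay, for the compounds shown here, a 3.1-fold higher number from compound 3 to compound 4 (0.49 log units; beyond the scatter) is the only step on the carbon with a double bond to nitrogen that lies beyond the scatter, whereas a 1.6-fold higher number from compound 2 to compound 4 (0.20 log units; within the scatter) stays within it. This place therefore does respond to the ring exchange, but only thiophen-2-yl against 5-bromo-2-hydroxyphenyl separates, not thiophen-2-yl against 4-fluorophenyl. Going by these compounds alone, the full group on the amide-type nitrogen also costs more than any exchange at this place, with a 7.6-fold higher number from compound 1 to compound 4 (0.88 log units; beyond the scatter) on replacing the one nitrogen atom of compound 1; no measurement on these compounds accounts for any of these steps.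

Open, from the compounds shown here alone, is whether an open chain such as propyl, or a phenyl ring carrying a carboxylic acid, would sit nearer compound 1 than compound 4 does. Also open, going by these compounds, is whether the bromo or the hydroxy of 5-bromo-2-hydroxyphenyl carries the gap to thiophen-2-yl.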